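Benzyl for Methyl on the Thioether: Cytotoxicity Outlook

The source may report more compounds than this note shows. Statements on the series, on what has been measured and on what is new or still open speak of the compounds shown alone.

Compound 1 `COc1cc(-c2nnc(SC)n2/N=C/c2ccccc2)cc(OC)c1OC` — > 200000 nM
Compound 2 `COc1ccc(/C=N/n2c(SC)nnc2-c2cc(OC)c(OC)c(OC)c2)c(OC)c1` — > 200000 nM

In a functional assay on HepG2 cells (Homo sapiens) for cytotoxicity, read by MTT assay, with a stated time of 48 h (on this read-out higher numbers stand for weaker inhibition and lower numbers for stronger inhibition), compound 1 gives > 200000 nM, which is a limit of the assay rather than a number. Compound 2 in this assay gives > 200000 nM, again a limit and not a number. Among the compounds with values here, the single measured step, a step that the two limits leave unreadable from compound 1 to compound 2, therefore has no readable size, and compound 2 stands at the limit of > 200000 nM in this assay, at which 2 of the 2 values shown sit.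

The unmeasured compound 3 `COc1ccc(/C=N/n2c(SCc3ccccc3)nnc2-c2cc(OC)c(OC)c(OC)c2)c(OC)c1` differs from compound 2 by phenyl in place of hydrogen on a saturated chain carbon bound to a sulfur. Within the data shown here, the one measured step concerns a different place on the shared core and carries no readable size, so it gives neither a direction nor a magnitude to expect here. Compound 3 is accordingly expected to remain at the same limit, with an expected step of a number no higher from compound 2 to compound 3 (the limit leaves the size open). For compound 3 in this assay the estimate is 200000 nM, with a range from 100000 nM to 400000 nM.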

Compound 3, half-maximal inhibitory concentration: 60900 nM
Estimate against measurement, compound 3: 3.3-fold (0.52 log units) above; measured number below the stated range.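

Replacing methylsulfanyl with benzylsulfanyl gives an at least 3.2-fold lower number from compound 2 to compound 3 (0.51 log units; beyond the scatter) in this assay, so this position on the sulfur responds to the change in a way that can be read. Within the data shown here, the earlier step, from phenyl to 2,4-dimethoxyphenyl at a different place, cannot be read, and so the earlier compounds showed no response at any position. Compound 3 is the only compound shown that gives a number rather than a limit: the limit of > 200000 nM in this assay, at which 2 of the 3 values shown sit.

The compounds shown leave open whether the phenyl ring itself matters here or whether a longer chain on the sulfur, such as butyl, would do the same. They also leave open whether benzylsulfanyl would give a readable value alongside the plain phenyl of compound 1, and how an amine or a carboxylic acid on the new ring would read.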